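The source may report more compounds than this note shows. Statements on the series, on what has been measured and on what is new or still open speak of the compounds shown alone.

Of the compounds shown here, three built on closely related cores have been tested in a functional assay on BT-549 cells (Homo sapiens) for cytotoxicity, read by sulforhodamine B assay, with a stated time of 48 h; on this read-out lower numbers stand for stronger inhibition of growth and higher numbers for weaker inhibition of growth. Compound 1 `ClCc1ccccc1Cn1cnc2c(Cl)nc(Cl)nc21` gives 1470 nM in this assay. Compound 2 `ClCc1ccccc1Cn1cnc2c(Cl)ncnc21` gives 5490 nM in this assay, and compound 3 `ClCc1ccc(Cn2cnc3nc(Cl)nc(Cl)c32)cc1` gives 3460 nM in this assay.

Compound 1 and compound 2 differ in a single place: hydrogen in place of chloro on an aromatic carbon. That change gave a 3.7-fold higher number from compound 1 to compound 2 (0.57 log units; beyond the scatter), so removing the chloro weakened growth inhibition by a modest but real amount. Compound 3 is made of the same atoms as compound 1 joined in a different way; the difference between the two cores is not broken down here. What the numbers show is that compound 3 gives a higher number than compound 1, while the values of compound 3 and compound 2 lie within the usual scatter of each other, so no order can be read between those two.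

Compound 4 `ClCc1ccc(Cn2cnc3ncnc(Cl)c32)cc1` has not yet been measured. It differs from compound 3 by hydrogen in place of chloro on an aromatic carbon. The surroundings of the changed atom are described in the same words as for the change from compound 1 to compound 2, so this is the same change applied to a different core. Because the first instance gave a 3.7-fold higher number from compound 1 to compound 2 (0.57 log units; beyond the scatter), a step of similar size is expected here, a 3.2-fold higher number from compound 3 to compound 4 (0.50 log units; beyond the scatter). Compound 4 is therefore expected to give about 11000 nM in this assay, most likely between 5000 nM and 25000 nM.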

Compound 4, concentration for total growth inhibition: 17000 nM
Beside the measured number, compound 4's estimate is 1.5-fold (0.19 log units) below it; measured number inside the range.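

Taking the chloro off the aromatic carbon between two ring nitrogen atoms again weakened growth inhibition in this assay, with a 4.9-fold higher number from compound 3 to compound 4 (0.69 log units; beyond the scatter). Set beside the earlier example, the two steps point the same way and cannot be told apart in size: the same change on two cores in this assay, a 3.7-fold higher number (0.57 log units; beyond the scatter) from compound 1 to compound 2 and a 4.9-fold higher number (0.69 log units; beyond the scatter) from compound 3 to compound 4, 1.3-fold (0.12 log units) apart, within the scatter of two such steps

So in this series, the effect of this change carried over from one core to the other, even though the two cores are built from the same atoms joined differently. Going by these compounds alone, this is only two pairs of compounds in a single cell assay, so it does not show that the step would keep its size on any further core or in other cells, and it does not explain why the chloro matters.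

The compounds shown compare only chloro and hydrogen at this position, leaving open how an amine, a methoxy group or a bromo there would affect growth inhibition. Also open, from the compounds shown here alone, is what would happen if the chloromethyl group, present in all four compounds, were replaced by a plain methyl or a hydroxymethyl group.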